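The compounds below may be only part of what the source reports. "The series", "measured", "known", "first", "only" and "open" are said of these compounds alone.

Working notes on the series, step from compound 1 to compound 4.

Compound 1 `CC1CCC(Nc2nc(C(F)(F)F)ccc2CNC(=O)C(C)c2ccc(NS(C)(=O)=O)c(F)c2)CC1` is the weaker of the two compounds with a number in a functional assay on CHO-K1 cells for antagonist activity at transient receptor potential cation channel subfamily V member 1 (Homo sapiens), read by FLIPR; on this read-out higher numbers stand for weaker inhibition and lower numbers for stronger inhibition: compound 1 gives 1130 nM. Compound 3 `CCCN(CCC)c1nc(C(F)(F)F)ccc1CNC(=O)C(C)c1ccc(NS(C)(=O)=O)c(F)c1` gives 14.7 nM, and compound 2 `CC(C(=O)NCc1ccc(C(F)(F)F)nc1NCc1cccnc1)c1ccc(NS(C)(=O)=O)c(F)c1` is reported in this assay as "not active" (no number reported), with no number. Compound 1 therefore stands at the high end of the numbers shown, with compound 3 its nearest neighbour.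

Compound 4 `CC(C(=O)NCc1ccc(C(F)(F)F)nc1N1CCC(O)CC1)c1ccc(NS(C)(=O)=O)c(F)c1` is not yet measured. It differs from compound 1 in one place: 4-hydroxypiperidin-1-yl in place of (4-methylcyclohexyl)amino on an aromatic carbon.

Within the data shown here, the only measured step touching this position is a 77-fold lower number from compound 1 to compound 3 (1.89 log units; beyond the scatter), where dipropylamino replaced (4-methylcyclohexyl)amino. The dipropylamino of compound 3 and the 4-hydroxypiperidin-1-yl of compound 4 both lack the amino hydrogen of (4-methylcyclohexyl)amino, so the step to compound 4 is expected to run in the same direction, toward a lower number in this assay, though its size is uncertain with a single step as guide. The inactivity of compound 2, which keeps the amino hydrogen, does not contradict this reading.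

For compound 4 the expected number in this assay is 150 nM, range 30 nM to 800 nM, an estimated step of a 7.5-fold lower number from compound 1 to compound 4 (0.88 log units; beyond the scatter).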

Compound 4, half-maximal inhibitory concentration: "not active" (no number reported)
Nothing numeric was reported for compound 4, so the estimate cannot be set against anything.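

In this assay, among these compounds, compound 4 gives "not active" (no number reported), so no step from compound 1 to compound 4 can be read. No measured evidence bears on this result. The compounds shown leave open whether any replacement of (4-methylcyclohexyl)amino other than the dipropylamino of compound 3 gives a lower number than compound 1.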